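Replacing the sulfur-linked heterocycle with a phenylpiperazine

The source may report more compounds than this note shows. Statements on the series, on what has been measured and on what is new or still open speak of the compounds shown alone.

Compound 1 `Cn1c(-c2ccc(NC(=O)CSc3nc4ccccc4s3)cc2)nc(-c2ccccc2)c1-c1ccccc1`: in a functional assay on MCF7 cells (Homo sapiens) for cytotoxicity, read by MTT assay, with a stated time of 24 h, tested at 0.64 ug/mL (a lower number here means a weaker effect, a higher number a stronger effect of the compound at the concentration tested), compound 1 gives 0.9%.
Compound 2 `Cn1cnnc1SCC(=O)Nc1ccc(-c2nc(-c3ccccc3)c(-c3ccccc3)n2C)cc1`: in this assay compound 2 gives 33.1%.
Compound 3 `Cc1nnc(SCC(=O)Nc2ccc(-c3nc(-c4ccccc4)c(-c4ccccc4)n3C)cc2)s1`: in this assay compound 3 gives 35.1%.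

Compound 3 holds the highest of the three numbers, but its gap to compound 2 lies within the scatter, so those two cannot be ranked against each other; only compound 1 stands clearly apart, as a number 34.2 percentage points higher from compound 1 to compound 3 (beyond the scatter) shows. Compound 4 `Cn1c(-c2ccc(NC(=O)CN3CCN(c4ccccc4)CC3)cc2)nc(-c2ccccc2)c1-c1ccccc1` differs from compound 3 in one place: 4-phenylpiperazin-1-yl in place of (5-methyl-1,3,4-thiadiazol-2-yl)sulfanyl on a saturated chain carbon bound to a carbonyl carbon.

The measured steps that bear on this change all swap the group attached to the sulfur while keeping the sulfur itself: a number 32.2 percentage points higher from compound 1 to compound 2 (beyond the scatter) and a number 34.2 percentage points higher from compound 1 to compound 3 (beyond the scatter) were large, whereas a number 2 percentage points higher from compound 2 to compound 3 (within the scatter). Within the data shown here, in compound 4 the sulfur leaves too, and no measured pair covers such a change. The two small heterocycles gave similar numbers, while the 1,3-benzothiazol-2-yl group gave a far weaker one, so the outcome here is open. A weaker effect than compound 3 is expected, with wide uncertainty: compound 4 is estimated at 20%, expected between 3% and 45%, which means an expected step of a number 15.1 percentage points lower from compound 3 to compound 4 (beyond the scatter).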

Compound 4, a percentage reported as activity, at one concentration (the size of the read-out at that concentration, not a potency): 12.1%
Beside the measured number, compound 4's estimate is 7.9 percentage points above it, and the stated range covers the measured number.
By their numbers in this assay, from the lowest: compound 1; then compound 4; then compounds 2 and 3 (each within the scatter of the next).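

In this assay, among these compounds, this is the first change at the saturated chain carbon bound to a carbonyl carbon that removes the sulfur as well as the heterocycle, and compound 4 lands in the middle of the set, with a number 23 percentage points lower from compound 3 to compound 4 (beyond the scatter) and a number 21 percentage points lower from compound 2 to compound 4 (beyond the scatter) but a number 11.2 percentage points higher from compound 1 to compound 4 (beyond the scatter) in the opposite direction. Sulfur alone therefore does not set the order among these compounds: the sulfur-free compound 4 stands clearly above compound 1, which has sulfur, yet clearly below compounds 2 and 3, which also have it. No measurement here explains this order.

Compound 4 is the only compound shown without sulfur at this position, and its group also differs in size, with 12 heavy atoms where the group of compound 3 has 7, so the separate effects of losing the sulfur, losing the five-membered aromatic ring and adding the 4-phenylpiperazin-1-yl group remain unresolved. A 4-methylpiperazin-1-yl group or a morpholine ring in the same place would help to show whether the terminal phenyl ring or the piperazine ring matters more.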